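This account rests on a few compounds, and the source may have more. Where it says the series, first, only, none or still open, it means among the compounds named here.

Measured in a functional assay on A549 cells (Homo sapiens) for antiproliferative activity, with a stated time of 72 h, tested at 50 ug/mL; a lower number here means a weaker effect, a higher number a stronger effect of the compound at the concentration tested:
compound 1 `O=c1[nH]nc2n(c1=O)CCN2c1ccccc1` gives 17%
compound 2 `Cc1ccc(N2CCn3c2n[nH]c(=O)c3=O)cc1` gives 31%
compound 3 `O=c1[nH]nc2n(c1=O)CCN2c1ccc(Cl)cc1` gives 15%

Compound 3 has the lowest of the three numbers, but its nearest neighbour is compound 1, and that gap is within the scatter: a number 2 percentage points lower from compound 1 to compound 3 (within the scatter). Only the gap to compound 2 lies beyond the scatter: a number 16 percentage points lower from compound 2 to compound 3 (beyond the scatter).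

Compound 4 `COc1ccc(N2CCn3c2n[nH]c(=O)c3=O)cc1` differs from compound 3 as follows: methoxy in place of chloro on an aromatic carbon. Within the data shown here, no measured step exchanges chloro for methoxy, so the steps that bear on it are those at the same aromatic carbon: a number 2 percentage points lower from compound 1 to compound 3 (within the scatter), a number 14 percentage points higher from compound 1 to compound 2 (beyond the scatter) and a number 16 percentage points lower from compound 2 to compound 3 (beyond the scatter). They show that a change of the group on this carbon can move this assay by a modest amount, with methyl alone giving a number beyond the scatter; what methoxy does is not shown. A small rise from compound 3, close to the scatter, is therefore expected: a number 7 percentage points higher from compound 3 to compound 4 (within the scatter). Compound 4 is estimated at 22%, within 8% to 38%.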

Compound 4, a percentage reported as inhibition, at one concentration (the size of the read-out at that concentration, not a potency): 0%
Beside the measured number, compound 4's estimate is 22 percentage points above it; the whole stated range lies above it.
By their numbers in this assay, from the lowest: compound 4; then compounds 3 and 1 (each within the scatter of the next); then compound 2.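

Methoxy on this aromatic carbon, para to a large group, is the first group in the series to fall clearly below hydrogen in this assay (a number 17 percentage points lower from compound 1 to compound 4 (beyond the scatter)). It also falls clearly below chloro (a number 15 percentage points lower from compound 3 to compound 4 (beyond the scatter)), although chloro itself stays within the scatter of hydrogen, and the step from methyl is large (a number 31 percentage points lower from compound 2 to compound 4 (beyond the scatter)). This one position therefore moves the read-out in both directions from hydrogen, up with methyl and down with methoxy, and nothing measured here accounts for that split.

Going by these compounds, what a hydroxyl, an amine or a longer alkoxy chain such as ethoxy gives on this carbon remains open. On these data alone, whether the four numbers reflect any single trend across groups also remains open.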